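A few compounds are considered here, and "the series" means these few. Any claim that something is new, unique, unknown or untested is made for them only; others in the source may bear on it.

Compound 1 `Nc1cc(N)c2nc(-c3ccccc3)c(NCc3ccc(Cl)c(Cl)c3)nc2c1`: 20900 nM
Compound 2 `COc1cc(CNc2nc3cc(N)cc(N)c3nc2-c2ccccc2)cc(OC)c1OC`: 1510 nM
Compound 3 `CCOC(=O)[C@H](CCC(=O)O)NC(=O)c1ccc(Oc2nc3cc(N)cc(N)c3nc2-c2ccccc2)cc1`: 95500 nM

Of the compounds shown here, three built on one shared core have been tested in a functional assay on NCI-H460 cells (Homo sapiens) for inhibition, read by sulforhodamine B assay, with a stated time of 48 h; on this read-out lower numbers stand for stronger inhibition of growth and higher numbers for weaker inhibition of growth. Compound 1 stands second highest of the three numbers. Compound 3 gives a higher number, so it holds back cell growth less, and compound 2 gives a much lower number, so it holds back growth more; both gaps lie beyond the usual scatter of this assay.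

Compound 4 `Nc1cc(N)c2nc(-c3ccccc3)c(NCc3ccc(F)cc3)nc2c1` has not yet been measured. It differs from compound 1 in a single place: 4-fluorophenyl in place of 3,4-dichlorophenyl on a saturated chain carbon bound to a nitrogen on an aromatic ring. Within the data shown here, no measured pair shows this exact change, so nothing directly tells how large the step will be or which way it goes. Among the measured compounds shown here, the only guidance is that the benzyl substituent clearly matters here, since compound 2, which differs from compound 1 only in that group, lands far lower. Swapping two chlorines for one fluorine is a modest change, and the step from compound 1 to compound 4 is expected to be a 1.7-fold higher number from compound 1 to compound 4 (0.22 log units; within the scatter), a slight weakening that may not exceed the scatter. Compound 4 is therefore estimated at 35000 nM, with a likely range from 10000 nM to 120000 nM.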

Compound 4, concentration for 50% growth inhibition: 4070 nM
Beside the measured number, compound 4's estimate is 8.6-fold (0.93 log units) above it; measured number outside the range, below it.
By their numbers in this assay, from the lowest: compound 2; then compound 4; then compound 1; then compound 3.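

In this assay, placing 4-fluorophenyl in place of 3,4-dichlorophenyl on the saturated chain carbon gives a 5.1-fold lower number from compound 1 to compound 4 (0.71 log units; beyond the scatter), a step beyond the scatter. Compound 2 had hinted that this place matters, but this pair shows that even a swap between two halogen-bearing phenyl rings, with only one heavy atom fewer, can shift growth inhibition clearly, although compound 4 at 4070 nM still gives a higher number than compound 2 at 1510 nM. Nothing available here explains why the number falls.

This single step changes the number of chlorines and brings in fluorine together, so the contribution of each stays unresolved. As far as these compounds go, a plain benzyl or a 4-chlorobenzyl group at this place could help separate the two, and how either would compare with compound 4 remains open.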